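Notes on the step from compound 2 to compound 3

The compounds below may be only part of what the source reports. "The series", "measured", "known", "first", "only" and "open" are said of these compounds alone.

Measured so far in an ADME assay on PANC-1 cells (Homo sapiens) for cytotoxicity, read by MTT assay; on this read-out lower numbers stand for higher toxicity in this test and higher numbers for lower toxicity in this test:
Compound 1 `Cc1nc(-c2cccnc2)sc1-c1nnc(Cc2ccccc2)o1`: > 100 ug/mL (a limit)
Compound 2 `COc1ccccc1-c1nnc(-c2sc(-c3cccnc3)nc2C)o1`: > 100 ug/mL (a limit)

In this assay compound 2 gives > 100 ug/mL, which is a limit and not a number. The whole record so far is the limit of > 100 ug/mL in this assay, at which 2 of the 2 values shown sit. Within the data shown here, the only measured step is a step that the two limits leave unreadable from compound 1 to compound 2, so no size can be taken from it.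

Compound 3 `Cc1nc(-c2cccnc2)sc1-c1nnc(-c2ccncc2)o1` carries pyridin-4-yl in place of 2-methoxyphenyl on an aromatic carbon of the five-membered aromatic ring with 2 nitrogen and 1 oxygen: pyridin-4-yl in place of 2-methoxyphenyl on an aromatic carbon. Among the measured compounds shown here, no measured step gives a size or a direction for this change, so no step beyond the scatter is expected in this assay. This expectation rests on compound 2, whose > 100 ug/mL is a limit. The expected step is a number no higher from compound 2 to compound 3 (the limit leaves the size open). For compound 3 the estimated value is 100 ug/mL. The expected range for compound 3 runs from 40 ug/mL to 200 ug/mL, and another limit is the likeliest report.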

Compound 3, half-maximal cytotoxic concentration: > 100 ug/mL
Compound 3: no number, only a limit; the forecaster's own chance of this, stated with the estimate: 70%; the middle value lies on the limit itself.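

In this assay compound 3 gives > 100 ug/mL, a limit and not a number, so no new step can be read between compound 3 and either compound 1 or compound 2. All values in the series now sit at one limit: the limit of > 100 ug/mL in this assay, at which 3 of the 3 values shown sit. The compounds shown leave open whether compound 1, compound 2 and compound 3 differ at all in this test, and at what concentration any of them would show toxicity.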